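Triazole-Linked Coumarins: Styryl Replacing Dimethylaminophenyl

The source may hold more compounds than are shown below. What is called first, only, known or untested is meant among the compounds shown, and "the series" means these compounds.

Compound 1 `Cc1c(O)ccc2cc(-n3cc(-c4ccc(N(C)C)cc4)nn3)c(=O)oc12` and compound 3 `Cc1c(O)ccc2cc(-n3cc(/C=C/c4ccccc4)nn3)c(=O)oc12` share a hydroxylated core and differ only at the triazole substituent. In a functional assay on MCF7 cells (Homo sapiens) for antiproliferative activity (a lower number here means a stronger inhibitor, a higher number a weaker inhibitor), compound 3 gives 33700 nM. For compound 1 the result in this assay is only a limit, > 100000 nM. The step from compound 1 to compound 3 is therefore an at least 2.9-fold lower number from compound 1 to compound 3 (0.47 log units; beyond the scatter), made by 2-phenylethenyl in place of 4-(dimethylamino)phenyl on an aromatic carbon; the size of this step rests on (the limit of > 100000 nM in this assay, at which 2 of the 3 values shown sit), so only its lower bound is known.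

Compound 2 `CO[C@@H]1[C@@H](O)[C@@H](O)[C@H](Oc2ccc3c(c2C)OC(=O)C(n2cc(-c4ccc(N(C)C)cc4)nn2)C3)OC1(C)C` carries a sugar on a different, saturated core; how the two cores differ is not broken down here. In this assay compound 2 likewise gives only a limit, > 100000 nM.

Compound 4 `CO[C@@H]1[C@@H](O)[C@@H](O)[C@H](Oc2ccc3c(c2C)OC(=O)C(n2cc(/C=C/c4ccccc4)nn2)C3)OC1(C)C` is not yet measured and arises from compound 2 by 2-phenylethenyl in place of 4-(dimethylamino)phenyl on an aromatic carbon, the same change seen between compound 1 and compound 3. Because that change gave an at least 2.9-fold lower number from compound 1 to compound 3 (0.47 log units; beyond the scatter), the expected step is an at least 2.0-fold lower number from compound 2 to compound 4 (0.30 log units; that floor lies within the scatter), though nothing shows how the glycosylated core responds to it. Compound 4 is expected to give about 50000 nM, estimated between 15000 nM and 150000 nM.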

Compound 4, half-maximal inhibitory concentration: 14600 nM
Beside the measured number, compound 4's estimate is 3.4-fold (0.53 log units) above it; measured number outside the range, below it.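

In this assay, placing 2-phenylethenyl where 4-(dimethylamino)phenyl stood also lowers the number on the sugar-bearing core, giving an at least 6.8-fold lower number from compound 2 to compound 4 (0.83 log units; beyond the scatter). The change therefore acts in the same direction on both cores shown, and each step lies beyond the scatter, but this does not show that it has the same size on each core: the same change on two cores in this assay, an at least 2.9-fold lower number (0.47 log units; beyond the scatter) from compound 1 to compound 3 and an at least 6.8-fold lower number (0.83 log units; beyond the scatter) from compound 2 to compound 4; the limit leaves it open whether they differ Neither step has a known size, as each starts from a limit and gives only a lower bound: the limit of > 100000 nM in this assay, at which 2 of the 4 values shown sit.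

The compounds shown leave open whether the double bond of 2-phenylethenyl is needed, or whether a saturated two-carbon chain bearing a phenyl ring, a plain phenyl ring, or an amine on the phenyl ring of 2-phenylethenyl would serve as well. They also leave open what the sugar contributes on its own; no pair shown differs in the sugar alone.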